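The compounds below may be only part of what the source reports. "The series", "measured", "known", "first", "only" and "open" are said of these compounds alone.

Compound 2 `Cc1cc(C)c(S(=O)(=O)Nc2nnc(SCc3ccccc3)s2)c(C)c1` and compound 1 `O=S(=O)(Nc1nnc(SCc2ccc(Cl)cc2)s1)c1ccccc1` have both been run in a functional assay on MCF7 cells (Homo sapiens) for cytotoxicity, tested at 250 uM; on this read-out higher numbers stand for a weaker effect at the one concentration tested and lower numbers for a stronger effect. In this assay compound 2 gives 57%, the lowest of the two numbers in hand, and compound 1 gives 68%, a number higher by a margin beyond the usual scatter. Compound 3 `Cc1cc(C)c(S(=O)(=O)Nc2nnc(SCc3ccc(Cl)cc3)s2)c(C)c1` is not yet measured. It differs from compound 2 by a single change: chloro in place of hydrogen on an aromatic carbon. Going by the values given here, no measured pair isolates this change, so the step expected from compound 2 to compound 3 in this assay is small, a number 2 percentage points lower from compound 2 to compound 3 (within the scatter), and may fall within the scatter in either direction. Compound 3 is accordingly estimated at 55%, with a range from 40% to 72%.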

Compound 3, a percentage reported as activity, at one concentration (the size of the read-out at that concentration, not a potency): 61%
Compound 3: the middle estimate sits 6 percentage points below what was measured, within the range that was stated.
By their numbers in this assay, from the lowest: compounds 2, 3 and 1 (each within the scatter of the next, the first and the last beyond it).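

With 2,4,6-trimethylphenyl held on the sulfonyl sulfur, 4-chlorobenzyl in place of benzyl gives, in this assay, a number 4 percentage points higher from compound 2 to compound 3 (within the scatter), so chloro at this position produces no resolved shift. With 4-chlorobenzyl held, 2,4,6-trimethylphenyl in place of phenyl gives a number 7 percentage points lower from compound 1 to compound 3 (within the scatter), so that single change is not resolved either. No independent data bear on either step.

Open, going by these compounds, is whether a methoxy group or an amine in place of the chloro would move the read-out beyond the scatter. Also open, on these data alone, is whether a longer chain in place of the benzyl group would do so.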